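The source may report more compounds than this note shows. Statements on the series, on what has been measured and on what is new or still open speak of the compounds shown alone.

The measured compounds so far:
compound 1 `CCCCCCCNc1cc(-c2ccccc2)c(-c2ccccc2)nn1` gives 55000 nM in an assay on microsomes from liver for inhibition of sterol O-acyltransferase 1 (Rattus norvegicus); a higher number here means a weaker inhibitor, a lower number a stronger inhibitor;
compound 2 `CCCCCCCC[S+]([O-])c1cc(-c2ccccc2)c(-c2ccccc2)nn1` gives 92000 nM in this assay.

Both are weak inhibitors, and the gap between compound 1 and compound 2 lies within the usual scatter of repeated measurements, so the two cannot be told apart; compound 1 simply holds the number nearer to inhibition on the shared core. Compound 3 `O=C(O)CCCCCSc1cc(-c2ccccc2)c(-c2ccccc2)nn1` has not yet been measured in this assay. It differs from compound 1 in one place: (5-carboxypentyl)sulfanyl in place of heptylamino on an aromatic carbon. Among the compounds with values here, no step between two measured compounds is known here, so nothing shows how a change of this kind has moved the numbers before. With only weak inhibition to build on, compound 3 is expected to stay in the same weak range, with a step of a 1.1-fold higher number from compound 1 to compound 3 (0.04 log units; within the scatter) that is expected to lie at most modestly beyond the scatter in either direction. The value of compound 3 is estimated at 60000 nM, within a range from 15000 nM to 250000 nM.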

Compound 3, half-maximal inhibitory concentration: > 300000 nM
Compound 3 was reported as a limit; the forecaster's own chance of this, stated with the estimate: 30%; at least 5.0-fold (0.69 log units) between middle value and limit.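

In this assay, compound 3 gives > 300000 nM, which is a limit of the assay and not a number. Replacing heptylamino with (5-carboxypentyl)sulfanyl on this aromatic carbon gives an at least 5.4-fold higher number from compound 1 to compound 3 (0.73 log units; beyond the scatter), so inhibition on the shared core does respond to the group held here, something the values of compound 1 and compound 2, within the scatter of each other, could not show. How far the step extends cannot be read: the limit of > 300000 nM in this assay, at which 1 of the 3 values shown sits.

This single change alters both the atom joining the chain to the core and the end of the chain, so the compounds shown cannot say which of the two accounts for the loss. A plain hexylsulfanyl chain, or an amine at the end of the chain, would help to separate the two.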